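The source may report more compounds than this note shows. Statements on the series, on what has been measured and on what is new or still open speak of the compounds shown alone.

Compound 1 `Cc1nc(N)sc1CCCN/C(N)=N/C(=S)N[C@@H](C)c1ccccc1` gives 339 nM in an assay on membranes from Sf9 cells for displacement of a labelled ligand from histamine H2 receptor (Homo sapiens), read by scintillation counting, with a stated time of 60 min; a higher number here means a weaker inhibitor, a lower number a stronger inhibitor.
Compound 2 `CCCCCCNC(=O)/N=C(\N)NCCCc1sc(N)nc1C` gives 28.8 nM in this assay.
Compound 3 `CCC(NC(=O)/N=C(\N)NCCCc1sc(N)nc1C)c1ccccc1` gives 63.1 nM in this assay.

Among these three, compound 2 stands lowest in this assay; its nearest neighbour is compound 3, whose number lies beyond the scatter above it, and compound 1 lies far higher still. Compound 2 is therefore the strongest inhibitor of the three on the numbers shown.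

Compound 4 `Cc1nc(N)sc1CCCN/C(N)=N/C(=O)Nc1ccccc1` has not yet been measured. Compared with compound 2, it carries phenyl in place of hexyl on an amide-type nitrogen. Because compound 3 gives 63.1 nM with a phenyl-bearing group on that nitrogen while the hexyl of compound 2 gives 28.8 nM, the replacement by a bare phenyl is expected to cost some binding rather than gain it. The expected step from hexyl to phenyl is a 3.1-fold higher number from compound 2 to compound 4 (0.49 log units; beyond the scatter), a loss somewhat beyond the scatter. Compound 4 is therefore estimated to give 90 nM in this assay, with a likely range from 30 nM to 300 nM.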

Compound 4, inhibition constant: 3160 nM
Compound 4: the middle estimate sits 35-fold (1.55 log units) below what was measured; the whole stated range lies below it.
By their numbers in this assay, from the lowest: compound 2; then compound 3; then compound 1; then compound 4.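

In this assay the change of hexyl to phenyl on the amide-type nitrogen brings a 110-fold higher number from compound 2 to compound 4 (2.04 log units; beyond the scatter) even though both groups hold the same count of carbon atoms, so this place does not treat all such groups alike. Compound 3, with its phenyl-bearing group on that nitrogen, gives 63.1 nM and compound 4 gives 3160 nM in this comparison, so the presence of a phenyl ring alone does not set the number. No measurement offered here accounts for the size of this loss.

The compounds shown leave open whether a cyclohexyl on that nitrogen would stand nearer compound 2 or compound 4, which would separate the ring from its aromatic character. They also leave open how a benzyl group or a shorter chain such as butyl would fare at this place.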